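This account rests on a few compounds, and the source may have more. Where it says the series, first, only, none or still open, it means among the compounds named here.

Among the compounds with values here, compound 3 `COc1cccc(C(=O)Nc2cc(Sc3ncn[nH]3)c(O)c3ccccc23)c1` stands at the lower end of the two numbers so far: in a functional assay on PC-3 cells (Homo sapiens) for antiproliferative activity, read by MTT assay, with a stated time of 48 h (a lower number here means a stronger inhibitor, a higher number a weaker inhibitor), compound 3 gives 42100 nM. Its nearest neighbour is compound 1 `O=C(Nc1cc(Sc2ncn[nH]2)c(O)c2ccccc12)c1cccc(Cl)c1`, which in this assay gives 85600 nM, a change of a 2.0-fold lower number from compound 1 to compound 3 (0.31 log units; beyond the scatter). Compound 2 `COc1ccc(C(=O)Nc2cc(Sc3ncn[nH]3)c(O)c3ccccc23)cc1` reaches only a limit in this assay, > 100000 nM, as recorded in the limit of > 100000 nM in this assay, at which 1 of the 3 values shown sits; the steps of an at least 1.1-fold higher number from compound 1 to compound 2 (0.06 log units; that floor lies within the scatter) and an at least 2.3-fold lower number from compound 2 to compound 3 (0.37 log units; beyond the scatter) are therefore bounded on one side. Compound 4 `O=C(/C=C/c1ccc(Cl)cc1)Nc1cc(Sc2ncn[nH]2)c(O)c2ccccc12` differs from compound 3 by 2-(4-chlorophenyl)ethenyl in place of 3-methoxyphenyl on a carbonyl carbon. Within the data shown here, no measured step places an ethenyl between the carbonyl and the aryl ring; the only related evidence is the return of chloro, and there compound 1 was weaker than compound 3 by a 2.0-fold lower number from compound 1 to compound 3 (0.31 log units; beyond the scatter). A step of about that size toward a higher number, or none beyond the scatter, is expected, a 1.4-fold higher number from compound 3 to compound 4 (0.15 log units; within the scatter). Compound 4 is thus estimated at 60000 nM, within 20000 nM to 180000 nM.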

Compound 4, half-maximal inhibitory concentration: > 100000 nM
Compound 4 gave a limit, no number (the forecaster's own chance of this, stated with the estimate: 25%); middle value at least 1.6-fold (0.22 log units) from the limit.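

On the carbonyl carbon, 2-(4-chlorophenyl)ethenyl in place of 3-methoxyphenyl gives an at least 2.3-fold higher number from compound 3 to compound 4 (0.37 log units; beyond the scatter), so a change at this place can lose the modest activity of compound 3 in this assay. Against 3-chlorophenyl the step is only an at least 1.1-fold higher number from compound 1 to compound 4 (0.06 log units; that floor lies within the scatter), and the step involving compound 2 cannot be read. Compound 4 is a limit and joins compound 2 there: the limit of > 100000 nM in this assay, at which 2 of the 4 values shown sit.

Going by these compounds, it remains open whether the ethenyl or the 4-chlorophenyl carries this step. A 4-chlorophenyl on the carbonyl carbon, or an ethyl chain in place of the ethenyl, could separate the two.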